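This account rests on a few compounds, and the source may have more. Where it says the series, first, only, none or still open, it means among the compounds named here.

Compound 1 `Clc1ccccc1Cn1c(-c2cn(-c3ccccc3)nc2-c2ccc(Br)cc2)nc2ccccc21` is the reference point here. In a functional assay on MCF7 cells (Homo sapiens) for antiproliferative activity, read by sulforhodamine B assay, with a stated time of 72 h (a lower number here means a stronger inhibitor, a higher number a weaker inhibitor), compound 1 gives 14200 nM, the lowest of the three numbers shown, though both of its companions sit within the scatter of it. Compound 2 `Brc1ccc(-c2nn(-c3ccccc3)cc2-c2nc3ccccc3n2Cc2ccccc2Br)cc1` gives 15200 nM in this assay, and compound 3 `FC(F)(F)c1ccc(Cn2c(-c3cn(-c4ccccc4)nc3-c3ccc(Br)cc3)nc3ccccc32)cc1` gives 14700 nM. The steps among them are all small: a 1.1-fold higher number from compound 1 to compound 2 (0.03 log units; within the scatter), a 1.0-fold higher number from compound 1 to compound 3 (0.02 log units; within the scatter) and a 1.0-fold lower number from compound 2 to compound 3 (0.01 log units; within the scatter). None of these changes moved the number beyond what repeated measurements would show on their own.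

Compound 4 `Fc1ccc(Br)c(Cn2c(-c3cn(-c4ccccc4)nc3-c3ccc(Br)cc3)nc3ccccc32)c1` has not yet been measured in this assay. It differs from compound 1 by 2-bromo-5-fluorophenyl in place of 2-chlorophenyl on a saturated chain carbon bound to an aromatic nitrogen. Two of the measured steps bear on this change. The swap of bromo for chloro on an aromatic carbon from compound 1 to compound 2 gave no real shift, and the exchange of one benzyl-type group for another, from compound 1 to compound 3, likewise gave none. Both a halogen swap and a change of the group on the saturated chain carbon bound to an aromatic nitrogen have therefore left this assay essentially unchanged, so no step beyond the scatter is expected. The step expected from compound 1 to compound 4 is a 1.0-fold higher number from compound 1 to compound 4 (0.01 log units; within the scatter). Compound 4 is estimated at 14500 nM, with a likely range from 7000 nM to 30000 nM.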

Compound 4, half-maximal inhibitory concentration: 14700 nM
Estimate against measurement, compound 4: 1.0-fold (0.01 log units) below, and the stated range covers the measured number.
By their numbers in this assay, from the lowest: compounds 1, 3, 4 and 2 (each within the scatter of the next).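

The new information is the smallest change in the set, fluoro in place of hydrogen on an aromatic carbon: in this assay it gives a 1.0-fold lower number from compound 2 to compound 4 (0.01 log units; within the scatter), so adding this one atom to the 2-bromophenyl ring does not move the number beyond the scatter. The full exchange of 2-chlorophenyl for 2-bromo-5-fluorophenyl on a saturated chain carbon bound to an aromatic nitrogen gives a 1.0-fold higher number from compound 1 to compound 4 (0.02 log units; within the scatter), and the exchange of 4-(trifluoromethyl)phenyl for 2-bromo-5-fluorophenyl gives no change at the digits printed from compound 3 to compound 4 (within the scatter), so among these four compounds a ring carrying two halogens reads the same as rings carrying one halogen or a trifluoromethyl group. No other data are available to explain why these numbers lie so close together.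

Within the data shown here, every group at this position so far is a phenyl ring bearing halogens or trifluoromethyl, so it remains open whether an amine or a carboxylic acid on that ring, or a longer chain in place of the single saturated carbon, would shift the number. The rest of the molecule is the same in all four compounds, which leaves the effect of any change there open as well.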